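This account rests on a few compounds, and the source may have more. Where it says the series, first, only, none or still open, it means among the compounds named here.

Compounds 1, 2 and 3 share one core. Compound 1 is `CC(C)N(Cc1cccc(OCCCCCC(=O)O)c1)C(=O)c1ccc(-c2ccoc2)cc1`, and compound 2 `COc1cc(OC)cc(-c2ccc(C(=O)N(Cc3cccc(OCCCCCC(=O)O)c3)C(C)C)cc2)c1` and compound 3 `CCOC(=O)CCCCCOc1cccc(CN(C(=O)c2ccc(-c3ccoc3)cc2)C(C)C)c1` each differ from it in a single place. All three were tested in an ADME assay on Raji cells (Homo sapiens) for cytotoxicity, read by CellTiter-Glo and resazurin assay, with a stated time of 72 h; a higher number here means that more compound is needed for the effect, a lower number that less compound is needed. In this assay compound 1 reaches only the limit of the assay, > 26000 nM. Compound 2 likewise gives only the limit, > 26000 nM. Compound 3 also gives only the limit, > 26000 nM. So compound 3 stands where the other two stand, at the limit, with no number of its own. The two measured steps, a step that the two limits leave unreadable from compound 1 to compound 2 and a step that the two limits leave unreadable from compound 1 to compound 3, cannot be sized because of the limit of > 26000 nM in this assay, at which 3 of the 3 values shown sit.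

Compound 4, `CCOC(=O)CCCCCOc1cccc(CN(C(=O)c2ccc(-c3cc(OC)cc(OC)c3)cc2)C(C)C)c1`, differs from compound 3 by 3,5-dimethoxyphenyl in place of furan-3-yl on an aromatic carbon. The step from compound 1 to compound 2 is this same change, and both ends of it sat at the limit. Compound 4 is therefore expected to show a step that the limit leaves unreadable from compound 3 to compound 4, that is, nothing readable. Compound 4 is estimated at 40000 nM, with a range from 15000 nM to 100000 nM, most likely again reported only as the limit.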

Compound 4, half-maximal effective concentration: > 26000 nM
Compound 4: no number, only a limit; the forecaster's own chance of this, stated with the estimate: 85%; the middle value is on the limit's open side.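

Compound 4 also gives only a limit, so its steps from compound 3 and from compound 2 cannot be read, because all the compounds share the same limit: the limit of > 26000 nM in this assay, at which 4 of the 4 values shown sit.

The compounds shown leave open how large either change really is, and at what concentration, if any, these four compounds harm the cells.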